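The compounds below may be only part of what the source reports. "The series", "measured", "known", "first", "only" and "open" are said of these compounds alone.

Compound 2 `O=C(Nc1ccc(Cl)c(C(F)(F)F)c1)Nc1nnc(Sc2ncnc3scc(-c4ccncc4)c23)s1` is the starting point. In a functional assay on HUVEC cells (Homo sapiens) for antiproliferative activity, read by MTT assay, with a stated time of 48 h (a lower number here means a stronger inhibitor, a higher number a weaker inhibitor), compound 2 gives 18400 nM. Among the measured compounds shown here, only one other compound has been measured so far: compound 1 `O=C(Nc1ccccc1)Nc1nnc(Sc2ncnc3scc(-c4ccncc4)c23)s1`, which in this assay gives 19300 nM. The two numbers are close, the step of a 1.0-fold lower number from compound 1 to compound 2 (0.02 log units; within the scatter), so neither can be called stronger than the other.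

Compound 3 `COc1cccc(NC(=O)Nc2nnc(Sc3ncnc4scc(-c5ccncc5)c34)s2)c1` differs from compound 2 only at the same place that was changed between compound 1 and compound 2: 3-methoxyphenyl in place of 4-chloro-3-(trifluoromethyl)phenyl on an amide-type nitrogen. For the measured compounds named here, the one measured step that bears on this position, a 1.0-fold lower number from compound 1 to compound 2 (0.02 log units; within the scatter), shows that swapping the group on that amide-type nitrogen between phenyl and 4-chloro-3-(trifluoromethyl)phenyl left the number essentially unchanged. On that basis the 3-methoxyphenyl variant is expected to behave much the same, with no step beyond the scatter, a 1.0-fold higher number from compound 2 to compound 3 (0.00 log units; within the scatter). For compound 3 the expected value is therefore 18500 nM, with a likely range from 9000 nM to 40000 nM.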

Compound 3, half-maximal inhibitory concentration: 67700 nM
Compound 3: middle estimate off by 3.7-fold (0.56 log units), on the low side, and the stated range ends below it.
By their numbers in this assay, from the lowest: compounds 2 and 1 (each within the scatter of the next); then compound 3.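

The group on this amide-type nitrogen can change the number after all: in this assay, the change to 3-methoxyphenyl gives a 3.7-fold higher number from compound 2 to compound 3 (0.57 log units; beyond the scatter), and adding methoxy to the plain phenyl gives a 3.5-fold higher number from compound 1 to compound 3 (0.55 log units; beyond the scatter). The earlier pair suggested that this position tolerated change, but compound 3 shows that not every group on this phenyl ring leaves the number unchanged, since 4-chloro-3-(trifluoromethyl)phenyl did not shift it beyond the scatter while 3-methoxyphenyl did. Nothing available explains why methoxy behaves differently here.

Among the compounds shown here, with only three compounds, it remains open whether this weaker result is specific to methoxy or would also appear with a hydroxyl group or an amine on the same ring. As far as these compounds go, the effect of replacing the phenyl ring with a longer alkyl chain also remains unknown.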